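Bromo for fluoro on the aryl ring of compound 1

A few compounds are considered here, and "the series" means these few. Any claim that something is new, unique, unknown or untested is made for them only; others in the source may bear on it.

Compound 1, `CN/C(=N\CCC(c1ccc(F)cc1)c1ccccn1)NCCCc1c[nH]cn1`, was tested in a functional assay on cardiac atrium for agonist activity at histamine H2 receptor (Cavia porcellus) (on this read-out lower numbers stand for lower potency and higher numbers for higher potency (the scale is a negative logarithm)), where compound 1 gives 5.65. This is the lowest of the two numbers at hand. Among the compounds with values here, compound 2, `N=C(NCCCc1c[nH]cn1)NCCCC(c1ccccc1)c1ccccn1`, gives 6.61 in this assay, a value that stands higher than that of compound 1 by more than the usual scatter; no step between these two is described, so only their two values speak. Compound 3, `CN/C(=N\CCC(c1ccc(Br)cc1)c1ccccn1)NCCCc1c[nH]cn1`, has not yet been measured. It differs from compound 1 by bromo in place of fluoro on an aromatic carbon, para to a large group. Within the data shown here, no measured pair shows this exchange, so the step is expected to be small, in either direction or none beyond the scatter. The step from compound 1 to compound 3 is expected to be a number 0.15 log units higher from compound 1 to compound 3 (within the scatter). Compound 3 is therefore estimated at 5.8, with a range from 5.3 to 6.4.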

Compound 3, negative logarithm of the half-maximal effective concentration: 5.75
The estimate for compound 3 lay 0.05 log units above the measured number, within the range that was stated.
By their numbers in this assay, from the lowest: compounds 1 and 3 (each within the scatter of the next); then compound 2.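

In this assay, the change from 4-fluorophenyl to 4-bromophenyl gives a number 0.10 log units higher from compound 1 to compound 3 (within the scatter), the only exchange shown at this place. On this read-out, therefore, bromo and fluoro on this aromatic carbon, para to a large group, cannot be told apart on the core of compound 1. No measurement at hand bears on this result.

As far as these compounds go, it remains open whether a methoxy group, a trifluoromethyl group or an amine at this place would give a number beyond the scatter from compound 1. From the compounds shown here alone, it is also open whether fluoro or bromo on the phenyl ring of compound 2, which differs from compound 1 in more than one place, would leave its number as little changed.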